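This account rests on a few compounds, and the source may have more. Where it says the series, first, only, none or still open, it means among the compounds named here.

Compound 1 `CCN(c1ccc(C#N)c(Cl)c1)c1cc(-c2cccs2)ccc1C` gives 22000 nM in a functional assay on CWR22R cells (Homo sapiens) for antiproliferative activity, read by CCK-8 assay, with a stated time of 6 days; a higher number here means a weaker inhibitor, a lower number a stronger inhibitor.
Compound 3 `CCN(c1ccc(C#N)c(C(F)(F)F)c1)c1cc(-n2ccnc2)ccc1C` gives 16300 nM in this assay.
Compound 2 `CCN(c1cccc(-n2ccnc2)c1)c1ccc(C#N)c(Cl)c1` gives > 30000 nM in this assay, which is a limit of the assay and not a number.

Among the three measured compounds, compound 1 and compound 3 return numbers that lie within the usual scatter of each other, so no order can be read between them. For compound 2 only a limit is recorded, (the limit of > 30000 nM in this assay, at which 1 of the 3 values shown sits), and nothing more can be said of it.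

The next compound, compound 4 `CCN(c1ccc(C#N)c(Cl)c1)c1cc(-c2cn[nH]c2)ccc1C`, is derived from compound 1 by a single change: 1H-pyrazol-4-yl in place of thiophen-2-yl on an aromatic carbon. Among the measured compounds shown here, no measured pair in this set shows the effect of this exchange, so there is no step to lean on. What the measured compounds do show is that every number in this assay sits in the weak range, and compound 3, which also carries a nitrogen-containing five-membered aromatic ring in this place, gives 16300 nM.

On that basis compound 4 is expected to stay in the same weak range, with the step from compound 1 to compound 4 estimated as a 1.1-fold lower number from compound 1 to compound 4 (0.04 log units; within the scatter), not beyond the scatter. The estimated value for compound 4 in this assay is 20000 nM, expected to fall between 8000 nM and 50000 nM.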

Compound 4, half-maximal inhibitory concentration: > 30000 nM
Compound 4: only a limit was reported (the forecaster's own chance of this, stated with the estimate: 30%); at least 1.5-fold (0.17 log units) between middle value and limit.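

Among the compounds shown here, the exchange of thiophen-2-yl for 1H-pyrazol-4-yl gives the first reading of any change at this position, on an aromatic carbon para to a methyl group, and in this assay the step reads an at least 1.3-fold higher number from compound 1 to compound 4 (0.13 log units; that floor lies within the scatter). The result for compound 4, > 30000 nM, is a limit of the assay and not a number, so the step has only a floor and its full size cannot be read. Bringing in the 1H-pyrazol-4-yl ring, with its hydrogen-bond donor, did not bring the number down, and the limit now holds a second compound: the limit of > 30000 nM in this assay, at which 2 of the 4 values shown sit.

Whether any group at this position can move the number out of this weak range remains open, and the compounds shown give no step for an amine, a carboxylic acid or a longer chain in this place. As far as these compounds go, it is also open whether the same exchange would give a readable step on the core of compound 3, which carries trifluoromethyl where compound 1 carries chlorine.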